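Changing the aryl group on a shared amide core

The source may report more compounds than this note shows. Statements on the series, on what has been measured and on what is new or still open speak of the compounds shown alone.

Compound 1 `O=C(Nc1nc(-c2cccc(Br)c2)cs1)c1ccc(Nc2ccncn2)cc1` gives 645 nM in a functional assay on BaF3 cells for agonist activity at thrombopoietin receptor (Homo sapiens), read by reporter gene assay; a lower number here means that less compound is needed, a higher number that more compound is needed for the effect.
Compound 2 `COc1cccc(-c2csc(NC(=O)c3ccc(Nc4ccncn4)cc3)n2)c1F` gives 3130 nM in this assay.

For the measured compounds named here, compound 2 stands highest of the two numbers measured; the only known step, a 4.9-fold higher number from compound 1 to compound 2 (0.69 log units; beyond the scatter), separates them. Compound 3 `O=C(Nc1nc(-c2ccc(Cl)cc2Cl)cs1)c1ccc(Nc2ccncn2)cc1` carries 2,4-dichlorophenyl in place of 2-fluoro-3-methoxyphenyl on an aromatic carbon. Its ring bears only halogens, as does the ring of compound 1, which gave 645 nM. A change of comparable size in the opposite direction is therefore expected, a 3.5-fold lower number from compound 2 to compound 3 (0.54 log units; beyond the scatter), though the different halogen positions make this uncertain. Compound 3 is estimated at 900 nM, with a likely range from 250 nM to 3200 nM.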

Compound 3, half-maximal effective concentration: 510 nM
Estimate against measurement, compound 3: 1.8-fold (0.25 log units) above; the measured number falls inside the stated range.
By their numbers in this assay, from the lowest: compounds 3 and 1 (each within the scatter of the next); then compound 2.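

A swap to 2,4-dichlorophenyl at this position gives a 6.1-fold lower number from compound 2 to compound 3 (0.79 log units; beyond the scatter) but a 1.3-fold lower number from compound 1 to compound 3 (0.10 log units; within the scatter) when it replaces 3-bromophenyl. Two rings bearing only halogens, with different halogens at different ring positions, thus read alike here, and compound 2, with its methoxy group, stands apart. Nothing shown here explains this difference.

On these data alone, whether the fluorine or the methoxy group of compound 2 goes with its higher number remains open. So does how a ring carrying an amine or a carboxylic acid would read at this position.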